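This account rests on a few compounds, and the source may have more. Where it says the series, first, only, none or still open, it means among the compounds named here.

Of the compounds shown here, two have been measured. Compound 1 `CCN(CC)c1ccc(/C=N/NC(N)=S)c(O)c1` is one of them; in a functional assay on HeLa cells (Homo sapiens) for antiproliferative activity, read by MTT assay, with a stated time of 72 h (on this read-out lower numbers stand for stronger inhibition and higher numbers for weaker inhibition), compound 1 gives 2000 nM. Compound 2 `Oc1ccccc1/C=N/NC(=S)Nc1ccccc1` is the other; in this assay compound 2 gives 1500 nM. On the numbers shown compound 2 stands lowest of the two, but the gap to compound 1 lies within the usual scatter of repeated measurements, so no real order between them can be claimed.

Compound 3 `CCN(CC)c1ccc(/C=N/NC(=S)Nc2ccccc2)c(O)c1` has not yet been measured. It differs from compound 2 by diethylamino in place of hydrogen on an aromatic carbon. Going by the values given here, no single-point step between measured compounds exists here that would indicate what this change does, since compound 1 and compound 2 differ in more than one place. Given that compound 1 and compound 2 sit so close in this assay, the step of a 1.2-fold lower number from compound 2 to compound 3 (0.06 log units; within the scatter) is expected to be small, in either direction, and most likely within the scatter. For compound 3 in this assay a value of about 1300 nM is expected, plausibly ranging from 450 nM to 4000 nM.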

Compound 3, half-maximal inhibitory concentration: 700 nM
Compound 3: middle estimate off by 1.9-fold (0.27 log units), on the high side, within the range that was stated.
By their numbers in this assay, from the lowest: compound 3; then compounds 2 and 1 (each within the scatter of the next).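

In this assay, diethylamino in place of hydrogen on the aromatic carbon para to a large group gives a 2.1-fold lower number from compound 2 to compound 3 (0.33 log units; beyond the scatter), a modest step beyond the scatter, so this position accepts the group with a gain in inhibition. Phenyl in place of hydrogen on an amide-type nitrogen, with diethylamino already present, gives a 2.9-fold lower number from compound 1 to compound 3 (0.46 log units; beyond the scatter), also modest and beyond the scatter, which shows that each of the two changes counts when the other group is present, something compound 1 and compound 2 alone could not show. No evidence is available that accounts for either step. From the compounds shown here alone, it stays open whether dimethylamino, a ring amine such as morpholine or a methoxy group on this carbon would do the same. Also open, going by these compounds, is how a chlorine or methoxy group on the phenyl would alter the result.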